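The compounds below may be only part of what the source reports. "The series", "measured", "known", "first", "only" and "open" are said of these compounds alone.

Within the data shown here, compound 2, with the structure `CC(C)(C)N(NC(=O)c1ccccc1)C(=O)c1ccc(Cl)cc1Cl`, is the stronger of the two compounds measured so far in an assay on cells for agonist activity at ecdysone receptor (Bombyx mori), read by a luciferase reporter, with a stated time of 24 h; on this read-out higher numbers stand for an effect only at larger amounts of compound and lower numbers for an effect already at smaller amounts: compound 2 gives 117 nM, whereas compound 1, with the structure `CCc1ccccc1C(=O)N(NC(=O)c1ccccc1)C(C)(C)C`, gives 589 nM. Among the measured compounds shown here, the one step between them, a 5.0-fold lower number from compound 1 to compound 2 (0.70 log units; beyond the scatter), shows that exchanging the aryl group on this carbonyl carbon can move the read-out well beyond the usual scatter.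

Compound 3, with the structure `Cc1cc(C)cc(C(=O)N(NC(=O)c2ccccc2)C(C)(C)C)c1`, has not yet been measured in this assay. It differs from compound 2 in one place: 3,5-dimethylphenyl in place of 2,4-dichlorophenyl on a carbonyl carbon. For the measured compounds named here, no measured step covers this exact exchange; the only step that bears on it is the one from compound 1 to compound 2, which concerns the same carbonyl carbon and shows that the aryl group there matters. Because a 5.0-fold lower number from compound 1 to compound 2 (0.70 log units; beyond the scatter) was of modest size, a further change at the same place is expected to shift the number by a comparable amount, and the estimate for compound 3 is a step of a 2.9-fold lower number from compound 2 to compound 3 (0.47 log units; beyond the scatter) toward a lower number. Compound 3 is therefore expected to give about 40 nM, within a range from 10 nM to 160 nM.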

Compound 3, half-maximal effective concentration: 69.2 nM
Compound 3: middle estimate off by 1.7-fold (0.24 log units), on the low side; the measured number falls inside the stated range.
By their numbers in this assay, from the lowest: compounds 3 and 2 (each within the scatter of the next); then compound 1.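

In this assay, the exchange of 2,4-dichlorophenyl for 3,5-dimethylphenyl on this carbonyl carbon gives a 1.7-fold lower number from compound 2 to compound 3 (0.23 log units; within the scatter), so an aryl group carrying two chlorine atoms and one built of carbon only cannot be told apart here, although the atoms they carry differ. Among these compounds, the same 3,5-dimethylphenyl group in place of 2-ethylphenyl gives an 8.5-fold lower number from compound 1 to compound 3 (0.93 log units; beyond the scatter), which, together with the earlier step, sets compound 1 apart from both compound 2 and compound 3 and makes 2-ethylphenyl the one group of the three that stands out, with the higher number. Nothing is available that would explain either the close agreement of compound 2 and compound 3 or the distance of both from compound 1.

The three aryl groups differ both in what they carry and in where they carry it, so the compounds shown cannot separate these two influences at this carbonyl carbon. As far as these compounds go, it also remains open how the read-out would respond to an amine, a carboxylic acid or a longer chain on this aryl group.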